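Resolving the stereocentre of compound 3

This account rests on a few compounds, and the source may have more. Where it says the series, first, only, none or still open, it means among the compounds named here.

Compound 3 `CC(Nc1nc(C(=O)N2CCCC2)c2sccc2n1)c1cccnc1` gives the lowest number of the three measured compounds in a functional assay on CHO-K1 cells for antagonist activity at adenosine receptor A2b (Homo sapiens), read by FLIPR and calcium flux (a higher number here means a weaker inhibitor, a lower number a stronger inhibitor), at 13 nM. Among the measured compounds shown here, compound 1 `O=C(c1cncs1)c1nc(NCc2cccnc2)nc2ccsc12` gives 148 nM in this assay, and compound 2 `O=C(c1ccncc1)c1nc(NCc2cccnc2)nc2ccsc12` gives 869 nM; the one measured step, a 5.9-fold higher number from compound 1 to compound 2 (0.77 log units; beyond the scatter), concerns an exchange on the carbonyl carbon and so does not touch the change followed here. Compound 4 `C[C@@H](Nc1nc(C(=O)N2CCCC2)c2sccc2n1)c1cccnc1` differs from compound 3 only in that (the two compounds have the same atoms and bonds; at least one stereo element is drawn with a configuration in one of them and without one in the other: 1 of 1 stereo elements differ; a stereocentre at a saturated chain carbon is drawn without a configuration in compound 3 and R in compound 4). For the measured compounds named here, no measured step bears on a drawn configuration, so the expectation rests on the fact that compound 3 is drawn without one and compound 4 is a single enantiomer: if the drawn form carries the activity, the number should move down within the scatter; if not, it could move up considerably. Weighing both, compound 4 is expected near 9 nM, between 3 nM and 80 nM, a step of a 1.4-fold lower number from compound 3 to compound 4 (0.16 log units; within the scatter) in this assay.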

Compound 4, half-maximal inhibitory concentration: 3070 nM
Beside the measured number, compound 4's estimate is 340-fold (2.53 log units) below it, outside the stated range (above it).
By their numbers in this assay, from the lowest: compound 3; then compound 1; then compound 2; then compound 4.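

Fixing the saturated chain carbon as R gives a 240-fold higher number from compound 3 to compound 4 (2.37 log units; beyond the scatter) in this assay, so the configuration at this carbon matters a great deal, and the R form does not carry the activity seen for compound 3. Among the compounds shown here, the one earlier step concerned only the group on the carbonyl carbon and said nothing about this stereocentre. The gap can be tied to a single feature, since the two compounds have the same atoms and bonds: the fact that one of compounds 3 and 4 is drawn with a defined configuration and the other without, at the place where they differ

The compounds shown leave open whether the S form accounts for the low number of compound 3, and whether that form alone would match or pass it. As far as these compounds go, how an ethyl group on this carbon, or a piperidine amide in place of the pyrrolidine amide, would read in this assay also remains open.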